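A Second Bromine on a Hydrazone Already at the Limit

The source may report more compounds than this note shows. Statements on the series, on what has been measured and on what is new or still open speak of the compounds shown alone.

Compound 1 `Fc1ccc(/C=N/Nc2nc(-c3cc(C(F)(F)F)cc(C(F)(F)F)c3)cs2)cc1F` gives 16700 nM in a functional assay on HepG2 cells (Homo sapiens) for inhibition, read by MTT assay, with a stated time of 48 h; a higher number here means a weaker inhibitor, a lower number a stronger inhibitor. Compound 2 `COc1cc(/C=N/Nc2nc(-c3cc(C(F)(F)F)cc(C(F)(F)F)c3)cs2)cc(Br)c1OC` is reported in this assay only as a limit, > 100000 nM. Compound 3 `COc1ccccc1-c1csc(N/N=C/c2cc(OC)c(OC)c(Br)c2Br)n1`, built on a different core, is likewise reported only as the limit > 100000 nM in this assay. Compound 2 thus stands at the top of the numbers shown, at the limit of > 100000 nM in this assay, at which 2 of the 3 values shown sit. Compound 4 `COc1cc(/C=N/Nc2nc(-c3cc(C(F)(F)F)cc(C(F)(F)F)c3)cs2)c(Br)c(Br)c1OC` differs from compound 2 by bromo in place of hydrogen on an aromatic carbon. Among the measured compounds shown here, the only measured step, an at least 5.9-fold higher number from compound 1 to compound 2 (0.77 log units; beyond the scatter), runs toward that limit and says nothing about a second bromine. Compound 3 shows that a dibrominated dimethoxyphenyl also sits at the limit. Compound 4 is therefore expected to stay at or beyond the limit, the estimated step that the limit leaves unreadable from compound 2 to compound 4 showing no clear direction beyond the scatter. The estimated value of compound 4 in this assay is 150000 nM, in the range 40000 nM to 600000 nM.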

Compound 4, half-maximal inhibitory concentration: > 100000 nM
Compound 4 was reported as a limit; the forecaster's own chance of this, stated with the estimate: 80%; the middle value lies beyond the limit too.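

Among the compounds shown here, compound 2 and compound 4 are both reported only as limits, so no step between them can be read: the limit of > 100000 nM in this assay, at which 3 of the 4 values shown sit. The compounds shown leave open whether bromo in place of hydrogen on that aromatic carbon changes inhibition at all.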